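Longer Side Chain on a Shared Iminosugar Core

The source may hold more compounds than are shown below. What is called first, only, known or untested is meant among the compounds shown, and "the series" means these compounds.

Of the compounds shown here, two sharing one core have been measured in an assay on isolated protein (strain Wistar) for inhibition of lysosomal alpha-glucosidase (Rattus norvegicus), with a stated time of 30 min; a lower number here means a stronger inhibitor, a higher number a weaker inhibitor. Compound 1 `CC[C@@H]1N[C@@H](CO)[C@H](O)[C@H]1O` gives 2600 nM, and compound 2 `CCC[C@@H]1N[C@@H](CO)[C@H](O)[C@H]1O` gives 1700 nM. Going by the values given here, the only step measured so far is a 1.5-fold lower number from compound 1 to compound 2 (0.18 log units; within the scatter), which adds a methyl to the side chain. On these numbers compound 2 stands lowest of the two, with compound 1 nearest to it, though the gap between them lies within the scatter, so no order between them can be claimed.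

Compound 3 `CCCCC[C@@H]1N[C@@H](CO)[C@H](O)[C@H]1O` carries the change (ethyl in place of hydrogen on a saturated chain carbon, three bonds along the chain from a saturated ring carbon). Among the compounds with values here, the one measured step that bears on it, a 1.5-fold lower number from compound 1 to compound 2 (0.18 log units; within the scatter), points the same way, a longer saturated chain, and was small. The change here continues that chain one bond further out and adds more to it, so compound 3 is expected to move in the same direction, by a step of about a 1.9-fold lower number from compound 2 to compound 3 (0.28 log units; within the scatter), which may or may not clear the scatter. Compound 3 is therefore estimated at 900 nM in this assay, with a range from 300 nM to 2600 nM.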

Compound 3, half-maximal inhibitory concentration: 710 nM
The estimate for compound 3 lay 1.3-fold (0.10 log units) above the measured number; the range from low to high includes it.
By their numbers in this assay, from the lowest: compound 3; then compounds 2 and 1 (each within the scatter of the next).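

In this assay the series now holds a step along this side chain that clears the scatter: the ethyl in place of hydrogen, three bonds along the chain from a saturated ring carbon, gives a 2.4-fold lower number from compound 2 to compound 3 (0.38 log units; beyond the scatter), whereas the shorter extension gave only a 1.5-fold lower number from compound 1 to compound 2 (0.18 log units; within the scatter) and left compound 1 and compound 2 without an order. Read from the shortest chain shown, the propyl in place of hydrogen, two bonds along the chain from a saturated ring carbon, gives a 3.7-fold lower number from compound 1 to compound 3 (0.56 log units; beyond the scatter), so compound 3 stands apart from both of the other compounds, and this position accepts a longer saturated chain with a modest gain and no compound here going against it. Nothing in hand accounts for the size of these steps or says what the added carbons do.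

The compounds shown leave open whether a longer chain would lower the number further, level off or reverse the trend. They also leave open whether a branched chain, a phenyl ring or a hydroxyl or amine at the end of the chain would fit this position as the plain saturated chains do.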